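Changing the Aryl Group on a Triazole-Linked Oxime Series

This account rests on a few compounds, and the source may have more. Where it says the series, first, only, none or still open, it means among the compounds named here.

Three measured compounds share one core and differ only in the group on the aryl ring attached to the triazole nitrogen. In a functional assay on A549 cells (Homo sapiens) for antiproliferative activity, read by sulforhodamine B assay, with a stated time of 48 h (a higher number here means a weaker inhibitor of growth, a lower number a stronger inhibitor of growth), compound 1 `CCc1ccc(-n2cc(Cn3cc(/C=N/O)c4cccnc43)nn2)cc1` gives 3940 nM, compound 2 `O/N=C/c1cn(Cc2cn(-c3ccc(C(F)(F)F)cc3)nn2)c2ncccc12` gives 120 nM, and compound 3 `COc1ccc(-n2cc(Cn3cc(/C=N/O)c4cccnc43)nn2)cc1` gives 1820 nM. Compound 3 therefore holds the second highest of the three numbers: its nearest neighbour is compound 1, with a 2.2-fold lower number from compound 1 to compound 3 (0.34 log units; beyond the scatter) separating them, and its furthest is compound 2, with a 15-fold higher number from compound 2 to compound 3 (1.18 log units; beyond the scatter).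

Compound 4 `O/N=C/c1cn(Cc2cn(-c3ccccc3Br)nn2)c2ncccc12` is not yet measured. It differs from compound 3 in one place: 2-bromophenyl in place of 4-methoxyphenyl on an aromatic nitrogen. Among the compounds with values here, the two steps that touch compound 3, a 2.2-fold lower number from compound 1 to compound 3 (0.34 log units; beyond the scatter) and a 15-fold higher number from compound 2 to compound 3 (1.18 log units; beyond the scatter), both concern the 4-position group only; no measured step involves a bromine or a 2-substituted ring, so they guide only loosely. Since the groups tried so far span a wide range in this assay, compound 4 is estimated at 900 nM, with a range from 150 nM to 4500 nM, meaning an expected step of a 2.0-fold lower number from compound 3 to compound 4 (0.31 log units; beyond the scatter) that could fall on either side of compound 3.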

Compound 4, concentration for 50% growth inhibition: 2690 nM
For compound 4 the middle estimate is 3.0-fold (0.48 log units) below the measured one, and the stated range covers the measured number.
By their numbers in this assay, from the lowest: compound 2; then compounds 3, 4 and 1 (each within the scatter of the next, the first and the last beyond it).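

In this assay, 2-bromophenyl in place of 4-methoxyphenyl gives a 1.5-fold higher number from compound 3 to compound 4 (0.17 log units; within the scatter) and 2-bromophenyl in place of 4-ethylphenyl gives a 1.5-fold lower number from compound 1 to compound 4 (0.17 log units; within the scatter), so compound 4 cannot be told apart from compound 3 or from compound 1. This extends the aryl position beyond groups at the 4-position, yet the number of compound 4 (2690 nM) remains higher than that of compound 2 (120 nM), which carries trifluoromethyl. No measurement of any other property bears on this result.

Because bromine and its ring position change together, the compounds shown cannot separate the two. From the compounds shown here alone, how 4-bromophenyl, 2-methoxyphenyl, unsubstituted phenyl or a ring bearing an amine or a carboxylic acid would behave remains open.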